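A few compounds are considered here, and "the series" means these few. Any claim that something is new, unique, unknown or untested is made for them only; others in the source may bear on it.

Measured so far in a functional assay on MDA-MB-436 cells (Homo sapiens) for antiproliferative activity, read by MTT assay, with a stated time of 48 h; a higher number here means a weaker inhibitor, a lower number a stronger inhibitor:
- compound 1 `C=CS(=O)(=O)N1CCN(c2ncnc3sc(-c4ccc(C#N)cc4)cc23)CC1`: 9170 nM
- compound 2 `C=CS(=O)(=O)N1CCN(c2ncnc3sc(-c4cc(Br)cnc4F)cc23)CC1`: 28400 nM

Compound 2, at 28400 nM, holds the higher of the two numbers and is the weaker inhibitor of the pair. The next step leads to compound 3 `C=CS(=O)(=O)N1CCN(c2ncnc3sc(-c4c(C)noc4C)cc23)CC1`, with the change on an aromatic carbon next to the ring sulfur: 3,5-dimethyl-1,2-oxazol-4-yl in place of 5-bromo-2-fluoropyridin-3-yl on an aromatic carbon. Going by the values given here, only one measured step bears on this carbon: a 3.1-fold higher number from compound 1 to compound 2 (0.49 log units; beyond the scatter), a modest change. Among the compounds with values here, no measured compound carries 3,5-dimethyl-1,2-oxazol-4-yl, so the direction is weakly supported. Compound 2 sits at the high end of a narrow range, and compound 1 at 9170 nM marks the only lower point. In this assay, the expected change is again modest and toward a lower number: a 1.8-fold lower number from compound 2 to compound 3 (0.25 log units; within the scatter). Compound 3 is estimated at 16000 nM, with an expected range of 6000 nM to 45000 nM.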

Compound 3, half-maximal inhibitory concentration: 34600 nM
The estimate for compound 3 lay 2.2-fold (0.33 log units) below the measured number, within the range that was stated.
By their numbers in this assay, from the lowest: compound 1; then compounds 2 and 3 (each within the scatter of the next).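

In this assay, the step from the six-membered 5-bromo-2-fluoropyridin-3-yl to the five-membered 3,5-dimethyl-1,2-oxazol-4-yl gives a 1.2-fold higher number from compound 2 to compound 3 (0.09 log units; within the scatter), so this change on the aromatic carbon next to the ring sulfur does not separate the two groups. Going by these compounds alone, the second comparison gives a 3.8-fold higher number from compound 1 to compound 3 (0.58 log units; beyond the scatter), which leaves 4-cyanophenyl as the only group of the three set apart at this position, with both heteroaromatic rings beyond the scatter from it. No measurement shown here explains this grouping.

Going by these compounds, it remains open whether the separation of compound 1 belongs to the nitrile or to the phenyl ring, which an unsubstituted phenyl on this carbon would address. Also open, on these data alone, is how a carboxylic acid or an amine on the phenyl ring would read in this assay.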